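Replacing the carboxy group of compound 1

The source may hold more compounds than are shown below. What is called first, only, known or untested is meant among the compounds shown, and "the series" means these compounds.

For the measured compounds named here, in a functional assay on KBVIN cells (Homo sapiens) for cytotoxicity, read by sulforhodamine B assay, with a stated time of 3 days (a lower number here means that less compound is needed, a higher number that more compound is needed for the effect), compound 1 `Cc1coc(-c2ccc3c(c2O)CCCC3(C)C)c1C(=O)O` gives 4.7 uM, the lowest of the three numbers so far. Compound 3 `CCc1cccc2c(O)c(-c3occ(C)c3C(=O)O)ccc12` gives 23.6 uM and compound 2 `COc1c(-c2occ(C)c2C(=O)O)ccc2c1CCCC2(C)C` gives 47.8 uM. Going by the values given here, the one measured step, a 10-fold higher number from compound 1 to compound 2 (1.01 log units; beyond the scatter), is large, but it is methyl in place of hydrogen on an oxygen on an aromatic ring and does not touch the carboxy group. Compound 4 `Cc1coc(-c2ccc3c(c2O)CCCC3(C)C)c1CO` differs from compound 1 by hydroxymethyl in place of carboxy on an aromatic carbon. Among the compounds with values here, no measured step covers this change, so the expectation is anchored only on compound 1 at 4.7 uM and stays loose. A modest rise is expected, with the estimated step being a 1.9-fold higher number from compound 1 to compound 4 (0.28 log units; within the scatter). For compound 4 the estimated value is 9 uM, with an expected range of 2.5 uM to 32 uM.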

Compound 4, concentration for half-maximal effect: 19.9 uM
Beside the measured number, compound 4's estimate is 2.2-fold (0.34 log units) below it, and the stated range covers the measured number.
By their numbers in this assay, from the lowest: compound 1; then compounds 4 and 3 (each within the scatter of the next); then compound 2.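

In this assay, the carboxy position proves sensitive to change: hydroxymethyl in place of carboxy gives a 4.2-fold higher number from compound 1 to compound 4 (0.63 log units; beyond the scatter), yet compound 4 still gives a measured 19.9 uM, so the carboxy group is not needed for a reading in this assay. Both groups carry the same counts of hydrogen-bond donors and acceptors and no net charge, so those counts do not track the step. Nothing available bears on the reason for the step.

As far as these compounds go, whether a methyl ester or a primary amide at this position would fall closer to compound 1 or to compound 4 remains open. Also open, from the compounds shown here alone, is whether the same replacement gives a similar step on the core of compound 3.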